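What a hydroxy group may do to compound 2

The source may hold more compounds than are shown below. What is called first, only, known or untested is meant among the compounds shown, and "the series" means these compounds.

Compound 1 (`COc1ccc(/C=C2\COC/C(=C\c3ccccc3F)C2=O)cc1O`): 7500 nM
Compound 2 (`O=C1/C(=C/c2ccccc2)COC/C1=C\c1ccccc1F`): 9600 nM

Both numbers come from a functional assay on NCI-H1650 cells (Homo sapiens) for cytotoxicity, read by MTT assay, with a stated time of 72 h; on this read-out higher numbers stand for weaker inhibition and lower numbers for stronger inhibition. Compound 2 lies within the usual scatter of compound 1, so these two measurements cannot be ranked against each other.

Compound 3 (`O=C1/C(=C/c2cccc(O)c2)COC/C1=C\c1ccccc1F`) departs from compound 2 in a single place: hydroxy in place of hydrogen on an aromatic carbon. This is hydroxy in place of hydrogen on an aromatic carbon, which turns phenyl into 3-hydroxyphenyl.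

Among the measured compounds shown here, no measured pair shows this change on its own, so the evidence is thin. Compound 1 also carries a hydroxy group on an aromatic carbon and gives 7500 nM in this assay, but it differs from compound 3 in more than that one respect. A large shift therefore seems unlikely, and only a slight move toward stronger inhibition is expected.

The expected change is a 1.5-fold lower number from compound 2 to compound 3 (0.17 log units; within the scatter), which would stay within the scatter. For compound 3 the estimated value is 6500 nM, with an expected range from 2500 nM to 15000 nM (an estimate, not a measurement).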

Compound 3, half-maximal inhibitory concentration: 5700 nM
Compound 3: middle estimate off by 1.1-fold (0.06 log units), on the high side; the range from low to high includes it.
By their numbers in this assay, from the lowest: compounds 3, 1 and 2 (each within the scatter of the next).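

In this assay the change from phenyl to 3-hydroxyphenyl can now be read on its own: it gives a 1.7-fold lower number from compound 2 to compound 3 (0.23 log units; within the scatter) and so leaves the number within the scatter, which means this position carries a hydroxy group with no measurable gain or loss. Among the compounds shown here, compound 3 also allows the first comparison with compound 1 that differs in one place, and hydrogen in place of methoxy gives a 1.3-fold lower number from compound 1 to compound 3 (0.12 log units; within the scatter), again within the scatter, so the methoxy group of compound 1 makes no readable difference in this assay. Nothing measured here bears on why these numbers stay so close.

As far as these compounds go, whether a hydroxy group would read the same on another carbon of this ring remains open, as does the effect of changing the fluorine-bearing ring on the other side of the core. Also open, from the compounds shown here alone, is whether a different group at this position, such as an amine, a carboxylic acid or a longer chain like ethoxy, would shift the number beyond the scatter.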